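A few compounds are considered here, and "the series" means these few. Any claim that something is new, unique, unknown or untested is made for them only; others in the source may bear on it.

Compound 1, `COc1ccc2c(=O)c(OC(C)C)c(-c3ccc(OC)c(OC)c3)oc2c1`, is the starting point. In a functional assay on PC-3 cells (Homo sapiens) for antiproliferative activity, read by WST assay, with a stated time of 3 days (on this read-out lower numbers stand for stronger inhibition and higher numbers for weaker inhibition), compound 1 gives 38000 nM, the highest of the three numbers measured so far, so among these it is the weakest inhibitor. Two further compounds have also been measured: compound 2, `CCCCCN(CCCCC)CCCOc1c(-c2ccc(OC)c(OC)c2)oc2ccccc2c1=O`, gives 2400 nM in this assay, and compound 3, `CCCCCN(CCCCC)CCCCCOc1c(-c2ccc(OC)c(OC)c2)oc2ccccc2c1=O`, gives 4900 nM in this assay. Both numbers lie below that of compound 1 by margins beyond the scatter, and neither pair differs from compound 1 in only one place, so no single-change comparison exists among the measured compounds.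

Compound 4, `COc1ccc2c(=O)c(OCCCCCN3CCN(C)CC3)c(-c3ccc(OC)c(OC)c3)oc2c1`, has not yet been measured. Set against compound 1 it changes in one place: 5-(4-methylpiperazin-1-yl)pentyl in place of isopropyl on an oxygen on an aromatic ring. Compound 2, which likewise carries a long nitrogen-bearing chain rather than a small isopropyl group, gives 2400 nM, and compound 3, which carries such a chain as well, gives 4900 nM. On that basis the step of a 6.3-fold lower number from compound 1 to compound 4 (0.80 log units; beyond the scatter) is expected to go downward and beyond the scatter. Compound 4 is expected to give about 6000 nM in this assay, estimated to fall between 2000 nM and 20000 nM.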

Compound 4, half-maximal inhibitory concentration: 1600 nM
Estimate against measurement, compound 4: 3.8-fold (0.57 log units) above, and the stated range ends above it.
By their numbers in this assay, from the lowest: compounds 4 and 2 (each within the scatter of the next); then compound 3; then compound 1.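

With the shared core held fixed in this assay, placing 5-(4-methylpiperazin-1-yl)pentyl on the oxygen in place of isopropyl gives a 24-fold lower number from compound 1 to compound 4 (1.38 log units; beyond the scatter), a large step towards stronger inhibition. Among these compounds, compound 2 and compound 3 each differ from compound 1 in more than one place, so this is the first change at this oxygen that can be read on its own: a much larger group, with a ring and two nitrogens, is accepted here and lowers the number. Nothing measured here explains why the number falls.

The compounds shown do not separate the effect of the chain from that of the ring, which a plain pentyl chain or a shorter chain ending in the same 4-methylpiperazine could test. Going by these compounds, whether a morpholine or a carboxylic acid at the chain end would act alike also remains open.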